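Paw edema inhibition: methoxy in place of chloro

The source may report more compounds than this note shows. Statements on the series, on what has been measured and on what is new or still open speak of the compounds shown alone.

Measured so far:
compound 1, `COc1ccc(/C=C/C(=O)c2ccc(NC(=O)CO[N+](=O)[O-])cc2)cc1`: 53%
compound 2, `CC(=O)c1ccc(OCC(=O)Nc2ccc(C(=O)/C=C/c3ccc(Cl)cc3)cc2)cc1`: 61%

In a functional assay on the whole organism (strain albino) for inhibition, with Rattus norvegicus as the target, read by paw edema, with stated times of 30 min and 3 h, at a dose of 100 mg/kg by the oral route (a higher number here means more inhibition at the dose given (going by the name of the read-out), a lower number less inhibition), compound 2 gives 61%, the higher of the two numbers recorded so far; the nearest is compound 1, whose value lies within the scatter of that of compound 2, so no order between the two can be read. Compound 1 and compound 2 differ in more than one place, and their two values show only that both sit in the same band of inhibition in this assay.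

Compound 3, `COc1ccc(/C=C/C(=O)c2ccc(NC(=O)COc3ccc(C(C)=O)cc3)cc2)cc1`, is still to be measured in this assay. It is reached from compound 2 by the change (methoxy in place of chloro on an aromatic carbon). Within the data shown here, no measured pair isolates this change, so there is no measured step to lean on. Compound 1 carries the same methoxy and gives 53% in this assay, within the scatter of compound 2; on that basis the expected step is a number 3 percentage points lower from compound 2 to compound 3 (within the scatter), none beyond the scatter in either direction. Compound 3 is therefore estimated at 58% in this assay, with a range from 45% to 70%.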

Compound 3, a percentage reported as inhibition, in the whole organism at one dose (the size of the read-out at that dose, not a potency): 42%
Estimate against measurement, compound 3: 16 percentage points above; the measured number lies below the stated range.
By their numbers in this assay, from the lowest: compound 3; then compounds 1 and 2 (each within the scatter of the next).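

In this assay, methoxy in place of chloro on an aromatic carbon, para to a large group, now has a measured step of its own: a number 19 percentage points lower from compound 2 to compound 3 (beyond the scatter) with the 4-acetylphenyl group held constant, so this position is sensitive to the change. With methoxy held constant, 4-acetylphenyl in place of nitro on an oxygen on a saturated carbon gives a number 11 percentage points lower from compound 1 to compound 3 (beyond the scatter) as a second step beyond the scatter, so the group at that other end also matters, and the value of compound 1 cannot stand in for the effect of methoxy alone. Nothing in hand bears on why either step occurs.

Still open, as far as these compounds go, is whether the lower number is specific to methoxy or would also follow from other replacements of chloro on the same aromatic carbon, such as hydroxy, a dimethylamino group or a longer alkoxy chain. Also open, from the compounds shown here alone, is whether the chloro-to-methoxy step keeps its size with nitro on the oxygen, or with a carboxylic acid in place of the acetyl of the 4-acetylphenyl group.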